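Butyl(2-cyanoethyl)amino in place of dipropylamino on a triazine

This account rests on a few compounds, and the source may have more. Where it says the series, first, only, none or still open, it means among the compounds named here.

Measured compounds:
compound 1 `CCCN(CCC)c1nc(C)nc(N(CC)c2ccc(N(C)C)cc2C)n1`, 7 nM
compound 2 `CCN(c1nc(C)nc(N(CC2CC2)CC2CC2)n1)c1ccc(N(C)C)cc1C(F)(F)F`, 5 nM
compound 3 `CCCCN(CC)c1nc(C)nc(N(CC)c2ccc(OC(F)(F)F)cc2Br)n1`, 5 nM

Of the compounds shown here, three built on the shared core have been tested in an assay on isolated protein for binding affinity to corticotropin-releasing factor receptor 1 (Homo sapiens); on this read-out higher numbers stand for weaker inhibition and lower numbers for stronger inhibition. Compound 1 gives 7 nM in this assay, the highest of the three numbers, yet compound 2 with 5 nM and compound 3 with 5 nM both lie within the usual scatter of it, so the three cannot be ranked against each other.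

Compound 4 `CCCCN(CCC#N)c1nc(C)nc(N(CC)c2ccc(N(C)C)cc2C)n1` has not yet been measured. It differs from compound 1 in one place: butyl(2-cyanoethyl)amino in place of dipropylamino on an aromatic carbon. The group that enters is longer and brings a nitrile, which adds one hydrogen-bond acceptor.

For the measured compounds named here, no measured pair shows a change of this kind, so the expectation rests on the narrow spread of the three known values. Chains of similar size on this position give similar numbers, so the step of a 1.4-fold higher number from compound 1 to compound 4 (0.15 log units; within the scatter) is expected to stay small, at most a little toward weaker binding. Compound 4 is therefore expected to give about 10 nM in this assay, within a range from 3 nM to 35 nM.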

Compound 4, inhibition constant: 8 nM
Compound 4: middle estimate off by 1.3-fold (0.10 log units), on the high side; the measured number falls inside the stated range.
By their numbers in this assay, from the lowest: compounds 2, 3, 1 and 4 (each within the scatter of the next).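

Replacing dipropylamino with butyl(2-cyanoethyl)amino on the shared core gives, in this assay, a 1.1-fold higher number from compound 1 to compound 4 (0.06 log units; within the scatter). For the compounds shown here, this is the first comparison in the set between compounds that differ in one place, and it shows that the number at this position stays within the scatter when the entering group has more heavy atoms, a triple bond and an added hydrogen-bond acceptor. No measurement shown here offers an explanation for this result.

On these data alone, this change alters the chain and adds the nitrile at once, so the contribution of each remains open, and butyl(propyl)amino, which carries no nitrile, would help separate them. Also open, as far as these compounds go, is how the read-out would respond if a carboxylic acid or a primary amine stood at the chain end in place of the nitrile.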